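The source may hold more compounds than are shown below. What is called first, only, known or untested is meant among the compounds shown, and "the series" means these compounds.

Compound 1 `NC(=O)Cc1cc(=O)oc2cc(OCc3cccc(F)c3)ccc12` stands highest of the three numbers in an assay (strain Wistar) for inhibition of Amine oxidase [flavin-containing] A (Rattus norvegicus) (on this read-out lower numbers stand for stronger inhibition and higher numbers for weaker inhibition), at 70000 nM. Compound 2 `NC(=O)Cc1cc(=O)oc2cc(OCc3cccnc3)ccc12` gives 21000 nM, and compound 3 `NC(=O)Cc1cc(=O)oc2cc(OCc3ccncc3)ccc12` gives 26500 nM. The steps of a 3.3-fold lower number from compound 1 to compound 2 (0.52 log units; beyond the scatter) and a 2.6-fold lower number from compound 1 to compound 3 (0.42 log units; beyond the scatter) were modest yet beyond the scatter, whereas a 1.3-fold higher number from compound 2 to compound 3 (0.10 log units; within the scatter) lay within it. Compound 4 `CN(C)Cc1cc(=O)oc2cc(OCc3cccc(F)c3)ccc12` differs from compound 1 by dimethylamino in place of carbamoyl on a saturated chain carbon bound to an aromatic carbon. Within the data shown here, none of the measured steps touches this part of the shared core; all three vary the group on the saturated chain carbon bound to an oxygen on the aromatic ring, so no measured step bears directly on the change. Lacking such a precedent, one expects a step of no change at the digits printed from compound 1 to compound 4 (within the scatter) in this assay, within the scatter. Compound 4 is accordingly estimated at 70000 nM, with a range from 20000 nM to 250000 nM.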

Compound 4, half-maximal inhibitory concentration: > 100000 nM
Compound 4: a limit, no number; the forecaster's own chance of this, stated with the estimate: 25%; at least 1.4-fold (0.15 log units) between middle value and limit.
By their numbers in this assay, from the lowest: compounds 2 and 3 (each within the scatter of the next); then compound 1. At a limit, above all of these: compound 4.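

Compound 4 reads only as a limit, not as a number: the limit of > 100000 nM in this assay, at which 1 of the 4 values shown sits. This is the only change shown on the saturated chain carbon bound to an aromatic carbon, and in this assay dimethylamino in place of carbamoyl reads as an at least 1.4-fold higher number from compound 1 to compound 4 (0.15 log units; that floor lies within the scatter). The change therefore brings no stronger inhibition, but the floor of that step cannot show whether inhibition truly weakens.

As far as these compounds go, how far the true value lies past the limit stays open. So does how a carboxylic acid or a primary amine would read at this place.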